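Methoxy to hydrogen: working notes on a four-compound series

The source may report more compounds than this note shows. Statements on the series, on what has been measured and on what is new or still open speak of the compounds shown alone.

Measured compounds:
- compound 1, `COc1cc(-c2cc(/C=C/C(=O)c3ccc(N)cc3)[nH]n2)cc(OC)c1OC`: -40%
- compound 2, `COc1ccc(-c2cc(/C=C/C(=O)c3ccc(N)cc3)[nH]n2)cc1OC`: -40%
- compound 3, `COc1cc(C(=O)/C=C/c2cc(-c3cc(OC)c(OC)c(OC)c3)n[nH]2)cc(OC)c1OC`: -26%

All three were tested in a functional assay on RPMI-8226 cells (Homo sapiens) for cytotoxicity, read by sulforhodamine B assay, with a stated time of 48 h, tested at 100 uM; on this read-out lower numbers stand for a stronger effect and higher numbers for a weaker effect at the one concentration tested. Compound 1 gives -40% in this assay, and compound 2 gives -40%. The change between them is hydrogen in place of methoxy on an aromatic carbon, and the step of no change at the digits printed from compound 1 to compound 2 (within the scatter). Compound 3, in this assay, gives -26%; its values stand apart from those of compound 1 and of compound 2 beyond the scatter, but the difference between the core of compound 3 and the core of compound 1 is not broken down here.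

Compound 4, `COc1ccc(-c2cc(/C=C/C(=O)c3cc(OC)c(OC)c(OC)c3)[nH]n2)cc1OC`, is not yet measured. It differs from compound 3 by hydrogen in place of methoxy on an aromatic carbon. The place line is the same word for word as for the change from compound 1 to compound 2, so this is the same change made a second time, on the core of compound 3 instead of the core of compound 1. For the measured compounds named here, only one measured instance of the change exists, so the expectation rests on that single step.

Because the step of no change at the digits printed from compound 1 to compound 2 (within the scatter), the expected step of no change at the digits printed from compound 3 to compound 4 (within the scatter) is also within the scatter. Compound 4 is therefore estimated at -26% in this assay, with a likely range from -42% to -10%, anchored on compound 3 at -26%.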

Compound 4, a percentage reported as activity, at one concentration (the size of the read-out at that concentration, not a potency): -31%
The estimate for compound 4 lay 5 percentage points above the measured number; the measured number falls inside the stated range.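

Hydrogen in place of methoxy on an aromatic carbon, made on the core of compound 3, gives in this assay a number 5 percentage points lower from compound 3 to compound 4 (within the scatter). Set beside the earlier instance, the change carries from one core to the other with no difference that can be told from the scatter: the same change on two cores in this assay, no change at the digits printed (within the scatter) from compound 1 to compound 2 and a number 5 percentage points lower (within the scatter) from compound 3 to compound 4, 5 percentage points apart, within the scatter of two such steps. This supports treating the step as transferable between these two cores at this one place and at the one concentration tested, but two small steps on two cores do not establish a rule for the series, and a single-concentration read-out is not a potency, so differences that would appear at other concentrations remain unseen.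

The compounds shown carry only methoxy or hydrogen at this place, so it remains open how a larger or different substituent there, such as a hydroxyl, a chlorine atom or an amine, would read in this assay. Also open, on these data alone, is whether the same step would stay this small on a core that carries another group, such as a carboxylic acid, on the ring at the carbonyl end of the molecule.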